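Ester enlargement on the thienyl dihydropyrimidinone

A few compounds are considered here, and "the series" means these few. Any claim that something is new, unique, unknown or untested is made for them only; others in the source may bear on it.

Of the compounds shown here, three have been tested in an assay on membranes from HEK293 cells for displacement of a labelled ligand from adenosine receptor A2b (Homo sapiens), read by scintillation counting, with a stated time of 30 min, tested at 1 uM; on this read-out lower numbers stand for less inhibition and higher numbers for more inhibition at the one concentration tested (going by the name of the read-out). Compound 1 `CC1=C(C(=O)OC(C)(C)C)C(c2ccco2)NC(=O)N1C` gives 26%, compound 2 `CC1=C(C(=O)OC(C)(C)C)C(c2ccoc2)NC(=O)N1C` gives 16%, and the step of a number 10 percentage points lower from compound 1 to compound 2 (within the scatter) is small. Compound 3 `CCOC(=O)C1=C(C)N(C)C(=O)NC1c1ccsc1` gives 53%, the highest of the three, beyond the scatter from both others. Compound 4 `CC1=C(C(=O)OC(C)(C)C)C(c2ccsc2)NC(=O)N1C` differs from compound 3 by tert-butyl in place of ethyl on an oxygen next to a carbonyl group. Going by the values given here, no measured pair isolates this change; the only measured step concerns the aromatic ring, not the ester. Compounds 1 and 2 both carry the tert-butyl ester and sit lower than compound 3, but they differ in the ring as well. The author therefore expects for a number 11 percentage points lower from compound 3 to compound 4 (beyond the scatter) a modest downward step, possibly within the scatter. Compound 4 is estimated at 42%, between 22% and 62%.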

Compound 4, a percentage reported as inhibition, at one concentration (the size of the read-out at that concentration, not a potency): 35%
For compound 4 the middle estimate is 7 percentage points above the measured one; the range from low to high includes it.
By their numbers in this assay, from the lowest: compounds 2, 1 and 4 (each within the scatter of the next, the first and the last beyond it); then compound 3.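

Going by these compounds alone, the step of a number 18 percentage points lower from compound 3 to compound 4 (beyond the scatter) in this assay is the first reading of the ester position alone, with the thiophen-3-yl group held constant. With tert-butyl held constant, the ring also matters in one comparison: the step of a number 19 percentage points higher from compound 2 to compound 4 (beyond the scatter) stands beyond the scatter, whereas the step of a number 9 percentage points higher from compound 1 to compound 4 (within the scatter) does not. Nothing available explains these steps.

As far as these compounds go, how a methyl ester or a carboxylic acid would read at this position remains open. So does whether ethyl in place of tert-butyl would give a similar step on the furan compounds.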